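Ester chain extension and cytotoxicity across the series

The compounds below may be only part of what the source reports. "The series", "measured", "known", "first", "only" and "open" are said of these compounds alone.

Compound 3 `CCCCCCCCCCCCCCCCOC(=O)CCC(=O)N1CCN(CCCOc2cc3c(Nc4ccc(F)c(Cl)c4)ncnc3cc2OC)CC1` stands second highest of the three measured numbers in a functional assay on A549 cells (Homo sapiens) for cytotoxicity, read by MTT assay, with a stated time of 24 h, tested at 40 uM (a higher number here means a weaker effect of the compound at the concentration tested, a lower number a stronger effect), where compound 3 gives 82.6%. Its nearest neighbour is compound 2 `CCCCCCCCCCCCCCCOC(=O)CCC(=O)N1CCN(CCCOc2cc3c(Nc4ccc(F)c(Cl)c4)ncnc3cc2OC)CC1`, which in this assay gives 85.5%; the step of a number 2.9 percentage points lower from compound 2 to compound 3 (within the scatter) lies within the scatter. Compound 1 `CCCCCCCCCOC(=O)CCC(=O)N1CCN(CCCOc2cc3c(Nc4ccc(F)c(Cl)c4)ncnc3cc2OC)CC1` gives 17.9%, a number far apart from the other two, as the steps of a number 67.6 percentage points higher from compound 1 to compound 2 (beyond the scatter) and a number 64.7 percentage points higher from compound 1 to compound 3 (beyond the scatter) show.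

Compound 4 `CCCCCCCCCCCCCCCCCCCCOC(=O)CCC(=O)N1CCN(CCCOc2cc3c(Nc4ccc(F)c(Cl)c4)ncnc3cc2OC)CC1` differs from compound 3 only by butyl in place of hydrogen on a saturated chain carbon, ten or more bonds along the chain from an oxygen next to a carbonyl group. The measured step that bears most directly on this change is a number 2.9 percentage points lower from compound 2 to compound 3 (within the scatter), which lengthens the same chain at the same kind of place and shows nothing beyond the scatter. The large steps of a number 67.6 percentage points higher from compound 1 to compound 2 (beyond the scatter) and a number 64.7 percentage points higher from compound 1 to compound 3 (beyond the scatter) concern a much shorter chain and a place nine bonds along from the oxygen next to the carbonyl; both longer chains, in compounds 2 and 3, sit together at the high end. On this basis no movement beyond the scatter is expected, and the step from compound 3 to compound 4 is estimated as a number 0.4 percentage points higher from compound 3 to compound 4 (within the scatter). Compound 4 is therefore expected to give about 83%, within a range from 70% to 95%.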

Compound 4, a percentage reported as activity, at one concentration (the size of the read-out at that concentration, not a potency): 87.1%
The estimate for compound 4 lay 4.1 percentage points below the measured number; low and high end bracket the measured number.
By their numbers in this assay, from the lowest: compound 1; then compounds 3, 2 and 4 (each within the scatter of the next).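

In this assay, butyl in place of hydrogen on a saturated chain carbon, ten or more bonds along the chain from an oxygen next to a carbonyl group, gives the step of a number 4.5 percentage points higher from compound 3 to compound 4 (within the scatter), and pentyl at the same kind of place gives the step of a number 1.6 percentage points higher from compound 2 to compound 4 (within the scatter), so neither addition moves the number beyond the scatter and compounds 2, 3 and 4 form one group at the high end. Undecyl in place of hydrogen, nine bonds along the chain from that oxygen, gives the step of a number 69.2 percentage points higher from compound 1 to compound 4 (beyond the scatter), which keeps compound 1 as the only compound apart from the others, now against three longer chains rather than two. No evidence on the origin of this split is available for these compounds.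

The compounds shown leave open at which chain length between compound 1 and compound 2 the large step arises, a question that a dodecyl ester would bear on. They also leave open whether a carboxylic acid or an amine at the end of the long chain would keep the number at the level of compound 4.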